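The source may hold more compounds than are shown below. What is called first, only, known or untested is meant among the compounds shown, and "the series" means these compounds.

In an in vitro ADME assay on microsomes from liver (Rattus norvegicus) for metabolic stability, read by LC-MS (a lower number here means that the compound disappears faster, a higher number that the compound lasts longer), compound 3 (`N[C@@H]1CCCN(c2cc(=O)[nH]c(=O)n2Cc2ccccc2Br)C1`) stands at > 1.96 h which is a limit and not a number. Compound 2 (`N#Cc1ccccc1Cn1c(N2CCC[C@@H](N)C2)cc(=O)[nH]c1=O`) stands at > 3.33 h and this too is a limit. Among the measured compounds shown here, compound 1 (`N#Cc1ccccc1Cn1c(N2CCC[C@@H](N)C2)ncc(-c2ccoc2)c1=O`) gives 0.0667 h as a measured number, but no single-change step links it to the other two. Compound 4 (`Cn1c(=O)cc(N2CCC[C@@H](N)C2)n(Cc2ccccc2Br)c1=O`) comes from compound 3 through one change (methyl in place of hydrogen on an aromatic nitrogen), methyl in place of hydrogen on an aromatic nitrogen. For the measured compounds named here, the only measured step (a step that the two limits leave unreadable from compound 2 to compound 3) is bromo in place of cyano on an aromatic carbon, and it gives no readable size. Going by the values given here, no measured step covers the methyl change. No shift beyond the scatter is expected in this assay and no direction can be drawn from the data. The anchor for the expectation is compound 3 at > 1.96 h as a limit. The expected step (a step that the limit leaves unreadable from compound 3 to compound 4) is therefore a small one. For compound 4 the estimate is 2.5 h with an expected range from 0.8 h to 6 h and the result may come back only as a limit.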

Compound 4, half-life: 1.37 h
Estimate against measurement, compound 4: 1.8-fold (0.26 log units) above, and the stated range covers the measured number.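

In this assay, methyl in place of hydrogen on the aromatic nitrogen gives an at least 1.4-fold lower number from compound 3 to compound 4 (0.15 log units; that floor lies within the scatter) and compound 4 is the only one of the two 2-bromobenzyl compounds to read as a number and not as a limit. The floor of this step does not settle whether the full step goes beyond the scatter. From the compounds shown here alone, its true size stays unknown because compound 3 carries only a limit: the limit of > 1.96 h in this assay, at which 1 of the 4 values shown sits.

Going by these compounds, the step between the nitrile and bromo compounds cannot be read, so the methyl change remains untested with the nitrile in place of bromo. Also open, on these data alone, is how an ethyl group, or a longer chain ending in an amine or a carboxylic acid, on this same nitrogen would read in this assay against the methyl of compound 4.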